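Compound 2 to Compound 4: A Small Step Expected

The compounds below may be only part of what the source reports. "The series", "measured", "known", "first", "only" and "open" are said of these compounds alone.

In a physicochemical assay for pharmacokinetics (a higher number here means that the compound lasts longer, a lower number that the compound disappears faster), compound 1 (`O=C(NCc1ccccc1Br)N1C(=O)c2ccccc2S1(=O)=O`) gives 0.253 h and compound 3 (`O=C(NCc1ccc(C(F)(F)F)cc1)N1C(=O)c2ccccc2S1(=O)=O`) gives 0.212 h while compound 2 (`COc1ccc(CNC(=O)N2C(=O)c3ccccc3S2(=O)=O)cc1`) gives 0.187 h and so stands within the scatter of both. Compound 4 (`O=C(NCc1ccccc1Cl)N1C(=O)c2ccccc2S1(=O)=O`) is still unmeasured and differs from compound 2 by 2-chlorophenyl in place of 4-methoxyphenyl on a saturated chain carbon bound to an amide-type nitrogen with 2-chlorophenyl in place of 4-methoxyphenyl on a saturated chain carbon bound to an amide-type nitrogen. For the measured compounds named here, two measured steps bear on this change, 4-methoxyphenyl in place of 2-bromophenyl with a 1.4-fold lower number from compound 1 to compound 2 (0.13 log units; within the scatter) and trifluoromethyl in place of methoxy with a 1.1-fold higher number from compound 2 to compound 3 (0.05 log units; within the scatter) and both stay within the scatter. Hence no step beyond the scatter is expected in this assay and the estimated step is only a 1.2-fold higher number from compound 2 to compound 4 (0.09 log units; within the scatter) in size. For compound 4 the estimated half-life of 0.23 h spans 0.15 h to 0.35 h as its expected range.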

Compound 4, half-life: 0.42 h
Beside the measured number, compound 4's estimate is 1.8-fold (0.26 log units) below it; measured number outside the range, above it.
By their numbers in this assay, from the lowest: compounds 2, 3, 1 and 4 (each within the scatter of the next, the first and the last beyond it).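

In this assay, 2-chlorophenyl in place of 4-methoxyphenyl on a saturated chain carbon bound to an amide-type nitrogen gives a 2.2-fold higher number from compound 2 to compound 4 (0.35 log units; beyond the scatter), the only step shown that passes beyond the scatter, so a change at this position can move the half-life measurably. Chloro in place of bromo on an aromatic carbon gives a 1.7-fold higher number from compound 1 to compound 4 (0.22 log units; within the scatter), which stays within the scatter, so this swap does not separate the two compounds. Nothing available explains the rise in half-life. Every compound shown carries a substituted phenyl ring at this position, so the effect of an amine, a carboxylic acid or a longer chain there remains open.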